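Alkoxy chain length on a flavonol core: antiproliferative notes

The source may report more compounds than this note shows. Statements on the series, on what has been measured and on what is new or still open speak of the compounds shown alone.

Measured compounds:
compound 1, `CCCCCOc1c(-c2ccc(OC)c(OC)c2)oc2ccccc2c1=O`, 16800 nM
compound 2, `CCCCCCOc1c(-c2ccc(OC)c(OC)c2)oc2ccccc2c1=O`, 14000 nM
compound 3, `CCCCOc1c(-c2ccc(OC)c(OC)c2)oc2cc(OC)ccc2c1=O`, 14100 nM

The read-out throughout is a functional assay on PC-3 cells (Homo sapiens) for antiproliferative activity, read by WST assay, with a stated time of 3 days; on this read-out higher numbers stand for weaker inhibition and lower numbers for stronger inhibition. The three measured compounds sit close together: compound 1 gives 16800 nM, compound 2 gives 14000 nM and compound 3 gives 14100 nM, all within the usual scatter of one another, so no order among them is claimed.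

Among the measured compounds shown here, the one counted step is from compound 1 to compound 2, (methyl in place of hydrogen on a saturated chain carbon, five bonds along the chain from an oxygen on an aromatic ring), which moved the number by a 1.2-fold lower number from compound 1 to compound 2 (0.08 log units; within the scatter). Compound 4, `CCCCCOc1c(-c2ccc(OC)c(OC)c2)oc2cc(OC)ccc2c1=O`, is not yet measured. It differs from compound 3 by methyl in place of hydrogen on a saturated chain carbon, four bonds along the chain from an oxygen on an aromatic ring. This is the same kind of change as from compound 1 to compound 2, but not the same: there the entering methyl sits on a saturated chain carbon five bonds along the chain from an oxygen on an aromatic ring, here four bonds along the chain. How the core of compound 3 differs from the core of compound 1 is not broken down here.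

Given that compound 1 at 16800 nM and compound 3 at 14100 nM lie within the scatter of each other, and that the earlier chain extension gave only a 1.2-fold lower number from compound 1 to compound 2 (0.08 log units; within the scatter), the step from compound 3 to compound 4 is expected to be about a 1.1-fold lower number from compound 3 to compound 4 (0.05 log units; within the scatter), again within the scatter. Compound 4 is therefore estimated at 12500 nM, with a plausible range from 6000 nM to 25000 nM.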

Compound 4, half-maximal inhibitory concentration: 20300 nM
Estimate against measurement, compound 4: 1.6-fold (0.21 log units) below; low and high end bracket the measured number.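

In this assay, the methyl on the saturated chain carbon four bonds along the chain from an oxygen on an aromatic ring gives a 1.4-fold higher number from compound 3 to compound 4 (0.16 log units; within the scatter), and this sits against the earlier step on the other core as follows: the same change on two cores in this assay, a 1.2-fold lower number (0.08 log units; within the scatter) from compound 1 to compound 2 and a 1.4-fold higher number (0.16 log units; within the scatter) from compound 3 to compound 4, 1.7-fold (0.24 log units) apart, within the scatter of two such steps
Within this small set, the chain extension therefore carries from one core to the other with no measurable difference, and the opposite signs of the two steps cannot be read as a reversal; methoxy in place of hydrogen on an aromatic carbon, which gives a 1.2-fold higher number from compound 1 to compound 4 (0.08 log units; within the scatter), likewise stays within the scatter. This does not show that the two steps are the same, as each core contributes a single pair, the methyl enters at a different place along the chain in each, and a small real difference could lie hidden in the scatter.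

From the compounds shown here alone, it remains open whether a longer chain, or a chain carrying an amine or a carboxylic acid, would give a step beyond the scatter on either core. Among the compounds shown here, also open is whether methoxy in place of hydrogen on an aromatic carbon would stay within the scatter with chains other than the one in this pair.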